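Methoxyphenyl sulfone: a single swap on compound 1

This account rests on a few compounds, and the source may have more. Where it says the series, first, only, none or still open, it means among the compounds named here.

Measured so far:
compound 1 `COc1ccc2ncc(S(=O)(=O)c3ccc(C)c(Cl)c3)c(N3CCC(C)CC3)c2c1` — 85%
compound 2 `CC1CCN(c2c(S(=O)(=O)c3cc(Cl)cc(Cl)c3)cnc3ccc(F)cc23)CC1` — 69%
compound 3 `Cc1ccc(S(=O)(=O)c2cnc3c(F)cccc3c2N2CCC(C)CC2)cc1` — 93%

Of the compounds shown here, three sharing one core have been tested in an assay on isolated protein for displacement of a labelled ligand from metabotropic glutamate receptor 5 (Homo sapiens), with a stated time of 60 min, tested at 1 uM; a lower number here means less inhibition, a higher number more inhibition at the concentration tested (going by the name of the read-out). Compound 1 gives 85%, the second highest of the three numbers. Its nearest neighbour is compound 3, which in this assay gives 93%, a number within the scatter of compound 1. Compound 2 gives 69%, a number beyond the scatter below compound 1. Going by the values given here, no two of these three differ in only one place, so no single-change step between measured compounds is available.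

The compound still to be measured is compound 4 `COc1ccc(S(=O)(=O)c2cnc3ccc(OC)cc3c2N2CCC(C)CC2)cc1`. It differs from compound 1 in one place: 4-methoxyphenyl in place of 3-chloro-4-methylphenyl on a sulfonyl sulfur. Among the compounds with values here, with no measured step of this kind to lean on, the expectation rests on where compound 1 stands and on the spread of the three numbers. The step in this assay is expected to be modest and downward, a number 10 percentage points lower from compound 1 to compound 4 (within the scatter), though a result within the scatter of compound 1 would not surprise. Compound 4 is therefore estimated at 75%, with a range from 50% to 93%.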

Compound 4, a percentage reported as inhibition, at one concentration (the size of the read-out at that concentration, not a potency): 41%
Estimate against measurement, compound 4: 34 percentage points above, and the stated range ends above it.
By their numbers in this assay, from the lowest: compound 4; then compound 2; then compounds 1 and 3 (each within the scatter of the next).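

In this assay, the swap on the sulfonyl sulfur gives a number 44 percentage points lower from compound 1 to compound 4 (beyond the scatter), the first single-change step available, and it shows that the read-out is sensitive to which substituted phenyl group this position carries. The two groups match in their count of heavy atoms and in having one six-membered aromatic ring of carbon only, so those shared features do not by themselves preserve the read-out; they differ in that 3-chloro-4-methylphenyl contains chlorine and no hydrogen-bond acceptor, whereas 4-methoxyphenyl contains oxygen and one hydrogen-bond acceptor. The data shown offer no measurement that explains the size of this step.

This one step leaves open which part of the change matters most: the loss of the chloro group, the loss of the methyl group or the arrival of the methoxy group. Also open, on these data alone, is how the read-out would respond to an amine or a carboxylic acid on the phenyl ring at the sulfonyl sulfur, or to a longer chain in place of the methoxy group there.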